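The source may hold more compounds than are shown below. What is called first, only, known or untested is meant among the compounds shown, and "the series" means these compounds.

Within the data shown here, compound 2 `CCCCNc1nc(N)nc2c1CN(C(=O)c1scnc1C)CC2` gives the higher of the two numbers measured so far in an assay on HEK293 cells for agonist activity at Toll-like receptor 8 (Homo sapiens), read by a luciferase reporter, with a stated time of 6 h (a higher number here means that more compound is needed for the effect, a lower number that less compound is needed), at 5.6 uM, while compound 1 `CCCCNc1nc(N)nc2c1CN(Cc1ccccn1)CC2` gives 0.07 uM, the step of an 80-fold higher number from compound 1 to compound 2 (1.90 log units; beyond the scatter) separating them. Compound 3 `CCCCNc1nc(N)nc2c1CN(C(=O)c1cocn1)CC2` differs from compound 2 by 1,3-oxazol-4-yl in place of 4-methyl-1,3-thiazol-5-yl on a carbonyl carbon. Among the measured compounds shown here, the one measured step swapped a whole group on the ring amine rather than one aromatic ring for another on a carbonyl, so it does not bear directly on this change. With no closer guide, the expected step is a 1.1-fold higher number from compound 2 to compound 3 (0.03 log units; within the scatter), which is an estimate that stays within the scatter. Compound 3 is estimated at 6 uM, in a range from 1.5 uM to 25 uM.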

Compound 3, minimum effective concentration: 0.2 uM
Beside the measured number, compound 3's estimate is 30-fold (1.48 log units) above it, outside the stated range (below it).
By their numbers in this assay, from the lowest: compound 1; then compound 3; then compound 2.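

On a carbonyl carbon, the choice of aromatic ring turns out to matter a great deal: 1,3-oxazol-4-yl in place of 4-methyl-1,3-thiazol-5-yl gives a 28-fold lower number from compound 2 to compound 3 (1.45 log units; beyond the scatter) in the number. The carbonyl link therefore does not by itself set the large loss seen earlier, as the remaining difference is a 2.9-fold higher number from compound 1 to compound 3 (0.46 log units; beyond the scatter) and compound 1 still needs less compound. Nothing measured here explains the effect of this ring change. The change swaps sulfur for oxygen, removes the methyl and moves the ring's attachment point all at once, so these compounds cannot separate those contributions. Going by these compounds, whether 1,3-thiazol-5-yl without the methyl, or a phenyl ring on the carbonyl, would fall nearer compound 3 or compound 2 remains open.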